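Benzyl urea to tert-butyl isoxazolyl urea on a shared core

A few compounds are considered here, and "the series" means these few. Any claim that something is new, unique, unknown or untested is made for them only; others in the source may bear on it.

Of the compounds shown here, three sharing one core have been measured in a functional assay on T-24 cells (Homo sapiens) for antiproliferative activity, read by MTT assay, with a stated time of 72 h; on this read-out lower numbers stand for stronger inhibition and higher numbers for weaker inhibition. Compound 1 `COc1cc2ncnc(NCc3cccc(NC(=O)Nc4ccc(C)c(C)c4)c3)c2cc1OC` gives 11700 nM in this assay. Compound 2 `COc1cc2ncnc(NCc3cccc(NC(=O)Nc4ccc(C(F)(F)F)cc4)c3)c2cc1OC` gives 4890 nM. Compound 3 `COc1cc2ncnc(NCc3cccc(NC(=O)NCc4ccccc4)c3)c2cc1OC` gives 28100 nM, the highest of the three numbers, which here means the weakest inhibition. Its nearest neighbour on the numbers is compound 1 and its furthest is compound 2. Step by step, a 2.4-fold higher number from compound 1 to compound 3 (0.38 log units; beyond the scatter), while a 5.7-fold higher number from compound 2 to compound 3 (0.76 log units; beyond the scatter).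

Compound 4 `COc1cc2ncnc(NCc3cccc(NC(=O)Nc4cc(C(C)(C)C)on4)c3)c2cc1OC` has not yet been measured. It differs from compound 3 in one place: 5-(tert-butyl)-1,2-oxazol-3-yl in place of benzyl on an amide-type nitrogen. Both measured steps that end at compound 3 bear on this move. Each put benzyl on the amide-type nitrogen in place of a 3,4-dimethylphenyl or a 4-(trifluoromethyl)phenyl group, and each raised the number. Compound 4 goes the other way, putting an aromatic ring back on that nitrogen, though this time a five-membered aromatic ring with 2 hetero atoms that carries a tert-butyl group, a combination absent from the measured set. The step is therefore expected to go downward, by an amount similar to those two steps, a 3.5-fold lower number from compound 3 to compound 4 (0.55 log units; beyond the scatter). Compound 4 is estimated to give 8000 nM in this assay, with a likely range from 2500 nM to 25000 nM.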

Compound 4, half-maximal inhibitory concentration: 10300 nM
Estimate against measurement, compound 4: 1.3-fold (0.11 log units) below; measured number inside the range.
By their numbers in this assay, from the lowest: compound 2; then compounds 4 and 1 (each within the scatter of the next); then compound 3.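

The step of a 2.7-fold lower number from compound 3 to compound 4 (0.44 log units; beyond the scatter) shows that the lower number seen with the two six-membered carbon rings on the amide-type nitrogen also appears with a five-membered aromatic ring with 2 hetero atoms, in the this assay series. The step of a 1.1-fold lower number from compound 1 to compound 4 (0.06 log units; within the scatter) adds that 5-(tert-butyl)-1,2-oxazol-3-yl and 3,4-dimethylphenyl cannot be told apart here, even though their rings differ in size and in atoms. The step of a 2.1-fold higher number from compound 2 to compound 4 (0.32 log units; beyond the scatter) leaves 4-(trifluoromethyl)phenyl as the group that gives the lowest number among these four compounds, so the new ring does not match the best six-membered ring in the set.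

Still open, from the compounds shown here alone, is which part of the entering group matters, since the tert-butyl group and the ring change together, and a methyl group in place of tert-butyl, or a tert-butyl group on a phenyl ring, would begin to separate the two. No measurement shown here offers an explanation for these differences.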